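This account rests on a few compounds, and the source may have more. Where it says the series, first, only, none or still open, it means among the compounds named here.

Measured so far in a functional assay on SW-620 cells (Homo sapiens) for cytotoxicity, read by MTT assay, with a stated time of 48 h; on this read-out lower numbers stand for stronger inhibition and higher numbers for weaker inhibition:
compound 1 `CCCCCCCCNC(=O)[C@@H](NC(=O)c1ccccc1)[C@@H](C)O` gives 200000 nM
compound 2 `CCCCCCCCCCCCNC(=O)[C@@H](NC(=O)c1ccccc1)[C@@H](C)O` gives 200000 nM
compound 3 `CCCCCCCCCCCCCCCCCCNC(=O)[C@@H](NC(=O)c1ccccc1)[C@@H](C)O` gives 200000 nM

The three measured compounds share one core and differ only in the length of the saturated chain on the amide nitrogen. In this assay compound 3 stands level with compounds 1 and 2: the change no change at the digits printed from compound 1 to compound 3 (within the scatter) lies within the scatter, as do no change at the digits printed from compound 1 to compound 2 (within the scatter) and no change at the digits printed from compound 2 to compound 3 (within the scatter). Lengthening the chain therefore does not move the read-out at all among these three compounds.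

Compound 4 `CCCCCCCCCCCCCCCCCCNC(=O)[C@@H](NS(=O)(=O)c1cccs1)[C@@H](C)O` keeps the octadecyl chain of compound 3 and changes the other side of the core: (thiophen-2-yl)sulfonyl in place of benzoyl on an amine nitrogen. Within the data shown here, none of the measured steps touches that position; every one of them varies the chain, and each was flat. Among the measured compounds shown here, the data thus offer no step that bears directly on the benzoyl-to-sulfonyl exchange, only the observation that the series has so far been insensitive to the one change it explored.

For the measured compounds named here, with no measured step to lean on, the expectation for compound 4 is that the exchange leaves the read-out unmoved, the expected step of no change at the digits printed from compound 3 to compound 4 (within the scatter) being none beyond the scatter. Compound 4 is accordingly estimated at 200000 nM, with a range from 70000 nM to 400000 nM.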

Compound 4, half-maximal inhibitory concentration: > 200000 nM
Compound 4: only a limit was reported (the forecaster's own chance of this, stated with the estimate: 40%); the middle value sits exactly at the limit.
By their numbers in this assay, from the lowest: compounds 1, 2 and 3 (each within the scatter of the next).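

In this assay compound 4 gives > 200000 nM, which is a limit of the assay and not a number. The exchange of benzoyl for (thiophen-2-yl)sulfonyl on the amine nitrogen is the only change at this position among the compounds shown, and it reads as a number no lower from compound 3 to compound 4 (the limit leaves the size open), so the change gives no sign of a lower number here, though how much higher the number may lie cannot be told. Where the earlier compounds spoke only to the saturated chain on the amide nitrogen, this result extends the absence of any lower number to the other side of the shared core, with the reading resting on a single limit: the limit of > 200000 nM in this assay, at which 1 of the 4 values shown sits.

The compounds shown leave open whether any group on this amine nitrogen can lower the number at all, and whether the sulfonyl or the thiophene ring carries the outcome, a question that a phenylsulfonyl group on the same nitrogen would separate. They also leave open how this nitrogen behaves with a shorter chain on the amide nitrogen, or with a chain ending in an amine or a carboxylic acid.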